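The source may report more compounds than this note shows. Statements on the series, on what has been measured and on what is new or still open speak of the compounds shown alone.

Measured so far:
- compound 1 `CN(C)CN1C(=O)/C(=N\NC(=S)NO)c2cc(F)ccc21`: 599000 nM
- compound 2 `O=C1/C(=N\NC(=S)NO)c2cc(F)ccc2N1CN1CCN(c2ccc(Cl)cc2)CC1`: 194000 nM

In an ADME assay on MT4 cells (Homo sapiens) for cytotoxicity, read by spectrophotometry, with a stated time of 5 days (on this read-out lower numbers stand for higher toxicity in this test and higher numbers for lower toxicity in this test), compound 2 gives 194000 nM, the lower of the two numbers, and compound 1 gives 599000 nM. The gap between these two numbers lies beyond the scatter. Compound 3 `O=C1/C(=N\NC(=S)NO)c2cc(F)ccc2N1CN1CCN(c2ccccc2)CC1` differs from compound 2 by hydrogen in place of chloro on an aromatic carbon, with hydrogen in place of chloro on an aromatic carbon. Within the data shown here, no measured pair shows this change, so the expectation starts from compound 2 at 194000 nM. The expected change is a 1.2-fold higher number from compound 2 to compound 3 (0.09 log units; within the scatter), a slight rise that stays within the scatter. For compound 3 the estimated value is 240000 nM, with an expected range of 110000 nM to 500000 nM.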

Compound 3, half-maximal cytotoxic concentration: 251000 nM
The estimate for compound 3 lay 1.0-fold (0.02 log units) below the measured number; the measured number falls inside the stated range.
By their numbers in this assay, from the lowest: compounds 2 and 3 (each within the scatter of the next); then compound 1.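

Working from the first single-place pair in the series, the change from 4-chlorophenyl to phenyl gives a 1.3-fold higher number from compound 2 to compound 3 (0.11 log units; within the scatter) in this assay. At this place, para to a large group, chloro and hydrogen therefore cannot be told apart on this read-out. No supporting data bear on this result.

As far as these compounds go, whether an amine or a carboxylic acid at the same place would move the number beyond the scatter remains open. The compounds shown also leave open what a change of the fluoro on the shared core would do.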